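The compounds below may be only part of what the source reports. "The series", "measured", "known", "first", "only" and "open" are said of these compounds alone.

Measured so far in an assay on isolated protein for inhibition of Amine oxidase [flavin-containing] B (Homo sapiens), read by fluorescence and Amplex Red, with stated times of 15 min and 20 min; a lower number here means a stronger inhibitor, a higher number a weaker inhibitor:
compound 1 `Cc1ccc(/C=N/c2ccc(OCc3ccccc3)cc2)c(O)c1`, 24400 nM
compound 2 `Oc1ccc(F)cc1/C=N/c1ccc(OCc2ccccc2)cc1`, 15300 nM
compound 3 `Oc1cccc(/C=N/c2ccc(OCc3ccccc3)cc2)c1O`, 6870 nM

Compound 2 stands second highest of the three numbers. Its nearest neighbour is compound 1, the step of a 1.6-fold lower number from compound 1 to compound 2 (0.20 log units; within the scatter) lying within the scatter; the step of a 2.2-fold lower number from compound 2 to compound 3 (0.35 log units; beyond the scatter) to compound 3 is modest but beyond it.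

Compound 4 `COc1ccc(O)c(/C=N/c2ccc(OCc3ccccc3)cc2)c1` follows from compound 2 by methoxy in place of fluoro on an aromatic carbon. Both measured steps that alter the same aromatic ring bear on this change: a 1.6-fold lower number from compound 1 to compound 2 (0.20 log units; within the scatter) was within the scatter, and a 2.2-fold lower number from compound 2 to compound 3 (0.35 log units; beyond the scatter) was modest. The new substitution is a comparably small edit, so the expected step in this assay is at most modest, more likely within the scatter, with direction uncertain.

Compound 4 is therefore estimated at 12000 nM, range 5000 nM to 30000 nM, which means an expected step of a 1.3-fold lower number from compound 2 to compound 4 (0.11 log units; within the scatter).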

Compound 4, half-maximal inhibitory concentration: 10700 nM
The estimate for compound 4 lay 1.1-fold (0.05 log units) above the measured number, within the range that was stated.
By their numbers in this assay, from the lowest: compounds 3, 4, 2 and 1 (each within the scatter of the next, the first and the last beyond it).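

In this assay, the swap of fluoro for methoxy, para to a hydroxy group and meta to a large group, gives a 1.4-fold lower number from compound 2 to compound 4 (0.16 log units; within the scatter). Among the compounds shown here, this is the first change confined to this position, and it shows that the position accepts methoxy, with its hydrogen-bond acceptor, without a step beyond the scatter. Nothing available explains this result.

Still open, going by these compounds, is whether an amine or a carboxylic acid at this position would give a step beyond the scatter. A longer alkoxy chain, such as butoxy, also remains untested in the compounds shown here.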